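The source may report more compounds than this note shows. Statements on the series, on what has been measured and on what is new or still open speak of the compounds shown alone.

The study compares two measured sulfonamides and one compound still awaiting measurement. Compound 1 `CC(C)CN(c1ccc(N(C)C)cc1)S(=O)(=O)c1ccc2c(c1)C(=O)CC(C1CCOCC1)O2` and compound 2 `CCc1ccc(N(CC(C)C)S(=O)(=O)c2ccc3cc(OCC4CCOCC4)c(C(=O)OC)cc3c2)cc1` were both run in a physicochemical assay for lipophilicity, at pH 7.4; a lower number here means a more polar compound, a higher number a more lipophilic compound. In this assay compound 1 gives 3.6, while compound 2 gives 6.09. Compound 2 therefore stands highest of the two numbers; its nearest neighbour is compound 1, whose value lies well below it, a gap beyond the usual scatter. Within the data shown here, the two compounds differ in more than one place, so no single step between them is drawn.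

The account now turns to compound 3 `CCc1ccc(N(CC(C)C)S(=O)(=O)c2ccc3cc(OCC4CCOCC4)c(C(=O)O)cc3c2)cc1`, which has not yet been measured. Compound 3 differs from compound 2 in one place only: hydrogen in place of methyl on an oxygen next to a carbonyl group. Cut one bond further out, the change reads methoxycarbonyl to carboxy.

Among the measured compounds shown here, with no measured pair showing this change, the expectation rests on the structural change alone. Compound 3 is expected to fall clearly below compound 2 in this assay, with an estimated step of a number 3.09 log units lower from compound 2 to compound 3 (beyond the scatter), well beyond the scatter. For compound 3 the estimated value in this assay is 3, with a range from 2 to 4.2.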

Compound 3, distribution coefficient: 1.77
Compound 3: middle estimate off by 1.23 log units, on the high side; measured number outside the range, below it.
By their numbers in this assay, from the lowest: compound 3; then compound 1; then compound 2.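

In this assay, among these compounds, the change from methoxycarbonyl to carboxy, hydrogen in place of methyl on an oxygen next to a carbonyl group, gives a number 4.32 log units lower from compound 2 to compound 3 (beyond the scatter) as the first step in this study that can be read at a single place. With everything else in the two structures held the same, this one position alone moves the read-out across a wide span, even though the change removes only a single heavy atom, one carbon. Nothing measured here accounts for the size of this step, which therefore stands as an observation without an established cause.

The compounds shown give this change on one background only, so it remains open whether the same replacement would produce a step of similar size on the core of compound 1 or on any other core. Also open, from the compounds shown here alone, is where other groups in this place would fall relative to compound 2 and compound 3, for instance an ethyl ester with its longer chain, a primary amide or a nitrile.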